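The compounds below may be only part of what the source reports. "The series", "measured", "known", "first", "only" and "open" are said of these compounds alone.

In an ADME assay on MT4 cells (Homo sapiens) for cytotoxicity, read by MTT assay, with a stated time of 96 h (a lower number here means that less compound is tolerated, a higher number that more compound is tolerated), compound 2 `NS(=O)(=O)c1ccc(N2N=C(c3ccc(Oc4ccccc4)cc3)CC2c2ccccc2)cc1` gives 42000 nM. Among the numbers shown it stands highest, though compound 3 `NS(=O)(=O)c1ccc(N2N=C(c3ccc(OCc4ccccc4)cc3)CC2c2ccccc2Cl)cc1`, which gives 26000 nM in this assay, lies within the scatter of it. Compound 1 `NS(=O)(=O)c1ccc(N2N=C(c3ccc(OCc4ccccc4)cc3)CC2c2ccccc2)cc1` returns only a limit in this assay, > 100000 nM (the limit of > 100000 nM in this assay, at which 1 of the 3 values shown sits). Two measured steps start from compound 1: an at least 2.3-fold lower number from compound 1 to compound 2 (0.37 log units; beyond the scatter), and an at least 3.8-fold lower number from compound 1 to compound 3 (0.58 log units; beyond the scatter).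

Compound 4 `NS(=O)(=O)c1ccc(N2N=C(c3ccc(Oc4ccccc4)cc3)CC2c2ccccc2F)cc1` has not yet been measured in this assay. It differs from compound 2 in one place: fluoro in place of hydrogen on an aromatic carbon. The change sits on an aromatic carbon of a six-membered aromatic ring of carbon only, ortho to a large group, and read one bond further out it is phenyl to 2-fluorophenyl.

Among the measured compounds shown here, the step that bears on it is the one from compound 1 to compound 3, where chloro in place of hydrogen on the same kind of aromatic carbon gave an at least 3.8-fold lower number from compound 1 to compound 3 (0.58 log units; beyond the scatter). Fluoro in place of hydrogen is a smaller version of that change, so a modest lowering of the number for compound 4 is expected, estimated at a 1.7-fold lower number from compound 2 to compound 4 (0.23 log units; within the scatter). Compound 4 is therefore estimated at 25000 nM in this assay, with a range from 10000 nM to 60000 nM.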

Compound 4, half-maximal cytotoxic concentration: 36000 nM
Beside the measured number, compound 4's estimate is 1.4-fold (0.16 log units) below it, within the range that was stated.
By their numbers in this assay, from the lowest: compounds 3, 4 and 2 (each within the scatter of the next). At a limit, above all of these: compound 1.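

In this assay, among the compounds shown here, the new pair gives the first step at this place that runs between two real numbers: a 1.2-fold lower number from compound 2 to compound 4 (0.07 log units; within the scatter). Fluoro in place of hydrogen on this aromatic carbon, ortho to a large group, therefore leaves the number within the scatter where phenyl stands on the oxygen, so the position does not lower the number under every substitution. The earlier step on the same kind of carbon, an at least 3.8-fold lower number from compound 1 to compound 3 (0.58 log units; beyond the scatter), put chloro in place of hydrogen with benzyl on the oxygen and gives only a lower bound on its size, since it starts from a reading that is a limit and not a number: the limit of > 100000 nM in this assay, at which 1 of the 4 values shown sits.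

The two steps differ both in the halogen and in the group on the oxygen, and without chloro on compound 2 or fluoro on compound 1 the compounds shown cannot say which of these separates them. Also open, going by these compounds, is how this aromatic carbon responds to a group other than a halogen, such as an amine, a methoxy group or a carboxylic acid.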